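A shorter acid chain on the shared core

The compounds below may be only part of what the source reports. "The series", "measured", "known", "first", "only" and "open" are said of these compounds alone.

The compounds here share one core, an oxygen-containing ring system bearing a pendant phenyl ring, and differ in what hangs from the oxygen on each ring. Compound 1 `O=C(O)COc1ccc(-c2coc3cc(OCC(=O)O)ccc3c2=O)cc1` carries a carboxymethyl group on both ring oxygens. In an assay (Cricetulus griseus) for inhibition of aldehyde dehydrogenase, mitochondrial (Homo sapiens) (a lower number here means a stronger inhibitor, a higher number a weaker inhibitor), compound 1 reaches only the limit of the measurement, >> 9000 nM, so no number is known for it; it sits at the limit of >> 9000 nM in this assay, at which 1 of the 3 values shown sits. Compound 2 `CCCCC(Oc1ccc2c(=O)c(-c3ccc(O)cc3)coc2c1)C(=O)OCC`, with an ester and a free hydroxy on the pendant ring, gives 4500 nM in this assay. Compound 3 `O=C(O)CCCCCCCOc1ccc2c(=O)c(-c3ccc(O)cc3)coc2c1`, which carries a long acid chain on the core and a hydroxy on the pendant ring, gives 40 nM in this assay.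

Compound 4 `O=C(O)COc1ccc2c(=O)c(-c3ccc(O)cc3)coc2c1` is not yet measured. It differs from compound 1 in one place: hydrogen in place of carboxymethyl on an oxygen on an aromatic ring. Read one bond further out, carboxymethoxy becomes hydroxy, so compound 4 keeps the short acid chain on the core, as compound 3 keeps its long one.

Because compound 3 gives 40 nM with a free hydroxy on the pendant ring, a better result for compound 4 than compound 1 shows seems plausible, and the step of an at least 1.8-fold lower number from compound 1 to compound 4 (0.25 log units; that floor lies within the scatter) is the size expected. Compound 4 is estimated at 5000 nM, within 800 nM to 30000 nM.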

Compound 4, half-maximal inhibitory concentration: 1200 nM
For compound 4 the middle estimate is 4.2-fold (0.62 log units) above the measured one; low and high end bracket the measured number.
By their numbers in this assay, from the lowest: compound 3; then compound 4; then compound 2. At a limit, above all of these: compound 1.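

Compound 1 is known only as a limit of the measurement: the limit of >> 9000 nM in this assay, at which 1 of the 4 values shown sits. In this assay, replacing carboxymethyl with hydrogen on an oxygen on an aromatic ring gives an at least 7.5-fold lower number from compound 1 to compound 4 (0.87 log units; beyond the scatter), so a carboxymethyl group on both ring oxygens is not needed for a measurable number, and the true size of this step may be larger than the printed floor. Among these compounds, the second step is the first direct reading of chain length with the free hydroxy kept in place: carboxy in place of 6-carboxyhexyl on the saturated chain carbon bound to an oxygen on an aromatic ring gives a 30-fold higher number from compound 3 to compound 4 (1.48 log units; beyond the scatter), so the long acid chain in compound 3 sits far ahead of the short one in compound 4.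

The compounds shown give only these two chain lengths with a free hydroxy, so how the number moves with chains of intermediate length remains open. Also open, going by these compounds, is whether an amine or a primary amide at the end of the long chain could stand in for the carboxylic acid, and whether a methoxy group could stand in for the free hydroxy.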